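From naphthalen-1-yl to 2-methylphenyl on an oxygen

The source may report more compounds than this note shows. Statements on the series, on what has been measured and on what is new or still open speak of the compounds shown alone.

Measured in a functional assay on MCF7 cells (Homo sapiens) for inhibition, read by MTT assay, with a stated time of 72 h (on this read-out lower numbers stand for stronger inhibition and higher numbers for weaker inhibition), are these compounds:
- compound 1 (`O=C(O)CCCCCCC(=O)Nc1ccc(C2=C(c3ccc(O)cc3)C3CC(S(=O)(=O)Oc4ccccc4C(F)(F)F)C2O3)cc1`) gives 26100 nM
- compound 2 (`O=C(O)CCCCCCC(=O)Nc1ccc(C2=C(c3ccc(O)cc3)C3CC(S(=O)(=O)Oc4cccc5ccccc45)C2O3)cc1`) gives 4700 nM

Compound 2 at 4700 nM has the lower of the two numbers. Compound 3 (`Cc1ccccc1OS(=O)(=O)C1CC2OC1C(c1ccc(NC(=O)CCCCCCC(=O)O)cc1)=C2c1ccc(O)cc1`) differs from it in one place (2-methylphenyl in place of naphthalen-1-yl on an oxygen) with 2-methylphenyl in place of naphthalen-1-yl on an oxygen. For the measured compounds named here, the one measured step that bears on this is a 5.6-fold lower number from compound 1 to compound 2 (0.74 log units; beyond the scatter) where naphthalen-1-yl replaced 2-(trifluoromethyl)phenyl. Returning to a one-ring group should undo part of that step, so a modest rise is expected in this assay for this change. The expected size is a 2.3-fold higher number from compound 2 to compound 3 (0.37 log units; beyond the scatter) by this estimate. The estimate for compound 3 is 11000 nM within a range of 4000 nM to 30000 nM overall.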

Compound 3, half-maximal inhibitory concentration: 7900 nM
Compound 3: the middle estimate sits 1.4-fold (0.14 log units) above what was measured; the range from low to high includes it.
By their numbers in this assay, from the lowest: compounds 2 and 3 (each within the scatter of the next); then compound 1.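

In this assay, the single ring of 2-methylphenyl on this oxygen does about as well as the two rings of naphthalen-1-yl, with a 1.7-fold higher number from compound 2 to compound 3 (0.23 log units; within the scatter). A one-ring group can therefore sit in the low group of numbers, and the choice of substituent on that ring counts: methyl in place of trifluoromethyl gives a 3.3-fold lower number from compound 1 to compound 3 (0.52 log units; beyond the scatter). No measurement available here explains this difference. The compounds shown leave open how an unsubstituted phenyl or a chlorophenyl group would compare on this oxygen, and so whether the methyl itself helps or trifluoromethyl simply hurts.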